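A few compounds are considered here, and "the series" means these few. Any claim that something is new, unique, unknown or untested is made for them only; others in the source may bear on it.

Compound 1, `Nc1cc(C2CCCC2)nc2ccc(NC(=O)/C=C/c3ccc(C(F)(F)F)cc3)cc12`, gives 0.8 nM in an assay on isolated protein for displacement of a labelled ligand from melanin-concentrating hormone receptor 1 (Homo sapiens) (a lower number here means a stronger inhibitor, a higher number a weaker inhibitor), the lowest number among the three measured compounds. Compound 2, `CCCc1cc(NC)c2cc(NC(=O)/C=C/c3ccc(C(F)(F)F)cc3)ccc2n1`, gives 1.5 nM, a value that sits within the usual scatter of compound 1, so the two cannot be told apart. Compound 3, `CCCc1cc(N)c2cc(NC(=O)/C=C/c3ccc(Cl)cc3)ccc2n1`, gives 6 nM, a higher number than compound 1 that lies beyond the scatter. Compound 4, `Nc1cc(-c2ccccc2)nc2ccc(NC(=O)/C=C/c3ccc(C(F)(F)F)cc3)cc12`, has not yet been measured. It differs from compound 1 in one place: phenyl in place of cyclopentyl on an aromatic carbon. Within the data shown here, no measured pair shows the effect of this change, so the expectation rests on compound 1 alone, and the step expected from compound 1 to compound 4 is a 2.5-fold higher number from compound 1 to compound 4 (0.40 log units; beyond the scatter), which may not exceed the scatter. Compound 4 is estimated at 2 nM, between 0.5 nM and 8 nM.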

Compound 4, half-maximal inhibitory concentration: 18.5 nM
The estimate for compound 4 lay 9.3-fold (0.97 log units) below the measured number, and the stated range ends below it.
By their numbers in this assay, from the lowest: compounds 1 and 2 (each within the scatter of the next); then compound 3; then compound 4.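

The position is not indifferent to the ring it carries: replacing the cyclopentyl with phenyl, one carbon ring for another, gives a 23-fold higher number from compound 1 to compound 4 (1.36 log units; beyond the scatter) in a single change. Neither ring has hydrogen-bond donors or acceptors, so this large step arises without any change in those counts. Nothing available explains the step.

On these data alone, it remains open whether ring size or aromatic character matters more, and cyclohexyl, with six ring carbons but no aromatic ring, would separate the two. As far as these compounds go, a pyridine ring in place of phenyl also remains untested here.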